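Methoxy in place of methyl at the weak end

The source may report more compounds than this note shows. Statements on the series, on what has been measured and on what is new or still open speak of the compounds shown alone.

In a functional assay on HL-60 cells (Homo sapiens) for cytotoxicity, read by XTT assay, with a stated time of 6 days (on this read-out lower numbers stand for stronger inhibition and higher numbers for weaker inhibition), compound 1 `c1coc(-c2ncnc3[nH]cc(Sc4cccs4)c23)c1` gives 7630 nM.

Compound 2 `Cc1ncnc2[nH]cc(Sc3cccs3)c12` gives > 25000 nM, which is a limit of the assay and not a number.

As far as these compounds go, compound 2 therefore stands only at the limit of > 25000 nM in this assay, at which 1 of the 2 values shown sits, and its true position remains open.

Compound 3 `COc1ncnc2[nH]cc(Sc3cccs3)c12` has methoxy in place of methyl on an aromatic carbon.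

Among the compounds with values here, the one measured step that bears on this change is an at least 3.2-fold higher number from compound 1 to compound 2 (0.51 log units; beyond the scatter), beyond the scatter, with methyl in place of furan-2-yl. It starts from another group and ends on a limit, so it gives no direct size for the methoxy change. No step beyond the scatter is therefore expected in this assay, and compound 3 may also return only a limit.

The expected step is an at least 1.1-fold lower number from compound 2 to compound 3 (0.05 log units; that floor lies within the scatter).

For compound 3 the estimated value is 22000 nM, with an expected range of 9000 nM to 50000 nM.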

Compound 3, half-maximal inhibitory concentration: > 25000 nM
Compound 3 ended at the assay's limit (the forecaster's own chance of this, stated with the estimate: 55%); middle value at least 1.1-fold (0.05 log units) from the limit.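

In this assay, compound 3 joins compound 2 at a limit of the assay, which is not a number, so this position now has two replacements for furan-2-yl without a measured value. Methoxy in place of furan-2-yl gives an at least 3.2-fold higher number from compound 1 to compound 3 (0.51 log units; beyond the scatter), which shows that the loss seen with methyl on this aromatic carbon also appears with methoxy. The step between compound 2 and compound 3 cannot be read, and methyl and methoxy cannot be ranked against each other, because both compounds sit at the same limit: the limit of > 25000 nM in this assay, at which 2 of the 3 values shown sit.

As far as these compounds go, how far either compound lies beyond that limit remains open. Also open, from the compounds shown here alone, is whether another group on this carbon, such as an amine or a phenyl ring, would return a measurable value as furan-2-yl does.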